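The compounds below may be only part of what the source reports. "The series", "measured", "known", "first", "only" and "open" are said of these compounds alone.

Compound 1 is `O=S(=O)(/C=C/c1ccccn1)c1ccc(F)cc1`, compound 2 is `O=S(=O)(/C=C/c1ccc(Cl)cn1)c1ccc(F)cc1`, compound 3 is `O=S(=O)(/C=C/c1ccccn1)c1ccc(Cl)cc1`, and compound 4 is `O=S(=O)(/C=C/c1ccc(Cl)cn1)c1ccc(Cl)cc1`. In an assay on U2OS cells for activation of nuclear factor erythroid 2-related factor 2 (Homo sapiens), read by beta-arrestin recruitment, with a stated time of 6 h (a lower number here means that less compound is needed, a higher number that more compound is needed for the effect), compound 1 gives 3100 nM, compound 2 gives 4370 nM and compound 3 gives 1730 nM. Compound 3 and compound 1 lie within the usual scatter of each other, while compound 2 stands beyond it with the higher number. Compound 4 differs from compound 3 by chloro in place of hydrogen on an aromatic carbon. The same change has been made once already, on the fluoro analogue: a 1.4-fold higher number from compound 1 to compound 2 (0.15 log units; within the scatter), a shift too small to count. Within the data shown here, the only other step, a 1.8-fold lower number from compound 1 to compound 3 (0.25 log units; within the scatter), also stays within the scatter. Accordingly only a small rise, if any, is expected: a 1.4-fold higher number from compound 3 to compound 4 (0.14 log units; within the scatter). Compound 4 is therefore estimated at 2400 nM, with a likely range of 1200 nM to 5000 nM.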

Compound 4, half-maximal effective concentration: 3160 nM
For compound 4 the middle estimate is 1.3-fold (0.12 log units) below the measured one; low and high end bracket the measured number.
By their numbers in this assay, from the lowest: compounds 3, 1, 4 and 2 (each within the scatter of the next, the first and the last beyond it).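

In this assay, chloro in place of hydrogen, two atoms from the ring nitrogen, can now be read on a second core, a 1.8-fold higher number from compound 3 to compound 4 (0.26 log units; within the scatter), and on neither core does the step leave the scatter: the same change on two cores in this assay, a 1.4-fold higher number (0.15 log units; within the scatter) from compound 1 to compound 2 and a 1.8-fold higher number (0.26 log units; within the scatter) from compound 3 to compound 4, 1.3-fold (0.11 log units) apart, within the scatter of two such steps. Chloro in place of fluoro also gets a second reading, a 1.4-fold lower number from compound 2 to compound 4 (0.14 log units; within the scatter), and the two readings agree: the same change on two cores in this assay, a 1.8-fold lower number (0.25 log units; within the scatter) from compound 1 to compound 3 and a 1.4-fold lower number (0.14 log units; within the scatter) from compound 2 to compound 4, 1.3-fold (0.11 log units) apart, within the scatter of two such steps.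

From the compounds shown here alone, what an amine, a carboxylic acid or a longer chain would do at this position stays open. So does whether any group there can move the number beyond the scatter.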